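A few compounds are considered here, and "the series" means these few. Any claim that something is new, unique, unknown or untested is made for them only; others in the source may bear on it.

Working notes on the series. Compound 2 `CCN(CC)c1cc(C)nc(N(CC)c2ccc(N(C)C)cc2Br)n1` gives 27 nM in an assay on isolated protein for binding affinity to corticotropin-releasing factor receptor 1 (Homo sapiens) (a higher number here means a weaker inhibitor, a lower number a stronger inhibitor), and stands highest of the three numbers to hand. Compound 1 `CCCCN(CC)c1cc(C)nc(N(CC)c2ccc(I)cc2Br)n1` gives 14 nM in this assay, a gap from compound 2 that stays within the scatter. For the measured compounds named here, compound 3 `CCN(CC)c1cc(C)nc(N(CC)c2ccc(N(C)C)cc2C(F)(F)F)n1` gives 11 nM in this assay, and the one single-point step recorded, a 2.5-fold lower number from compound 2 to compound 3 (0.39 log units; beyond the scatter), concerns a change at the position carrying the bromo group, not the position examined here.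

Compound 4 `CCN(CC)c1cc(C)nc(N(CC)c2ccc(I)cc2Br)n1` differs from compound 2 by iodo in place of dimethylamino on an aromatic carbon. Going by the values given here, no measured step covers this exchange. Compound 1 also carries the iodo group together with the bromo group and differs from compound 4 only in the amine on the shared core, so its value is the nearest point of reference; the values of compound 1 and compound 2 sit within the scatter of each other, and the step from compound 2 to compound 3 gives no guide on the iodo group at all.

The expected step is therefore small: from compound 2 to compound 4 a change of about a 1.6-fold lower number from compound 2 to compound 4 (0.20 log units; within the scatter) is estimated in this assay. For compound 4 the estimate is 17 nM, with a range from 6 nM to 45 nM.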

Compound 4, inhibition constant: 9 nM
Compound 4: middle estimate off by 1.9-fold (0.28 log units), on the high side; the measured number falls inside the stated range.
By their numbers in this assay, from the lowest: compounds 4, 3, 1 and 2 (each within the scatter of the next, the first and the last beyond it).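

In this assay, for the compounds shown here, iodo in place of dimethylamino gives a 3.0-fold lower number from compound 2 to compound 4 (0.48 log units; beyond the scatter) and so moves the number beyond the scatter at this position, meta to a bromo group and para to a large group, the first reading for this place. With iodo held in place, hydrogen in place of ethyl on a saturated chain carbon of the amine gives a 1.6-fold lower number from compound 1 to compound 4 (0.19 log units; within the scatter) and so cannot be told from the scatter. No measurement at hand accounts for the step at the iodo position.

From the compounds shown here alone, whether a chloro group, a methoxy group or a nitrile at this position would read closer to iodo or to dimethylamino stays open. Also open, going by these compounds, is whether the iodo exchange gives a like step with trifluoromethyl in place of bromo.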